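Chloro on the benzylidene ring: compound 4 from compound 1

This account rests on a few compounds, and the source may have more. Where it says the series, first, only, none or still open, it means among the compounds named here.

In a functional assay on K562 cells (Homo sapiens) for cytotoxicity, read by sulforhodamine B assay (a higher number here means that more compound is tolerated, a lower number that less compound is tolerated), compound 1 `CC1=CC[C@@H]([C@@](C)(O)CCCC(C)(C)NC(=S)N/N=C\c2ccccc2)CC1` gives only a limit, > 100000 nM. Compound 2 `COc1ccc(/C=N\NC(=S)NC(C)(C)CCC[C@](C)(O)[C@@H]2CC=C(C)CC2)cc1` likewise sits at a limit in this assay, > 100000 nM. Compound 3 `CC1=CC[C@@H]([C@@](C)(O)CCCC(C)(C)NC(=S)N/N=C\c2ccccc2Cl)CC1` gives 8500 nM in this assay, so an at least 11-fold lower number from compound 1 to compound 3 (1.07 log units; beyond the scatter) and an at least 11-fold lower number from compound 2 to compound 3 (1.07 log units; beyond the scatter), while a step that the two limits leave unreadable from compound 1 to compound 2 because of the limit of > 100000 nM in this assay, at which 2 of the 3 values shown sit. Compound 4 `CC1=CC[C@@H]([C@@](C)(O)CCCC(C)(C)NC(=S)N/N=C\c2ccc(Cl)cc2)CC1` has not been measured; the change from compound 1 is chloro in place of hydrogen on an aromatic carbon. For the measured compounds named here, the step to compound 3 brings the same chloro group, but not at the same aromatic carbon, so its size is the only guide and may not carry over fully. The expected step in this assay is an at least 3.3-fold lower number from compound 1 to compound 4 (0.52 log units; beyond the scatter), a lowering smaller than that to compound 3. Compound 4 is estimated at 30000 nM, with the range 6000 nM to 200000 nM, and a sizable chance that only a limit is recorded.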

Compound 4, concentration lethal to 50% of the cells: 10300 nM
For compound 4 the middle estimate is 2.9-fold (0.46 log units) above the measured one, and the stated range covers the measured number.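

In this assay, the effect of chloro is not tied to one ring carbon: the 4-chlorophenyl group gives an at least 9.7-fold lower number from compound 1 to compound 4 (0.98 log units; beyond the scatter), and the two chlorinated compounds cannot be told apart, with a 1.2-fold higher number from compound 3 to compound 4 (0.08 log units; within the scatter). At this same aromatic carbon, the identity of the group counts, with an at least 9.7-fold lower number from compound 2 to compound 4 (0.98 log units; beyond the scatter).

From the compounds shown here alone, whether a nitrile or an amine at this carbon would follow chloro or methoxy stays open. The full size of the steps from compound 1 and compound 2 also stays open because both sit at a limit: the limit of > 100000 nM in this assay, at which 2 of the 4 values shown sit.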